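Series notes: pyridinyl for phenyl on the shared core

The source may hold more compounds than are shown below. What is called first, only, known or untested is meant among the compounds shown, and "the series" means these compounds.

Compound 1 `COc1cccc(/C=C/C(=O)c2ccc(OC)c3c2OC(C)(C)C=C3)c1` is tested in a functional assay on K562 cells (Homo sapiens) for antiproliferative activity, read by MTT assay, with a stated time of 24 h (on this read-out higher numbers stand for weaker inhibition and lower numbers for stronger inhibition), and returns only the limit of the assay, > 10000 nM. Compound 2 `COc1ccc(C(=O)/C=C/c2cc(OC)c(OC)c(OC)c2)c2c1C=CC(C)(C)O2` also returns a limit, > 10000 nM. Compound 3 `COc1ccc(C(=O)/C=C/c2ccc(N(c3ccccc3)c3ccccc3)cc2)c2c1C=CC(C)(C)O2` likewise gives a limit, > 10000 nM. Going by the values given here, the series so far is summed up by the limit of > 10000 nM in this assay, at which 3 of the 3 values shown sit, so compound 1 stands with the others and no ordering among them is possible. Compound 4 `COc1ccc(/C=C/C(=O)c2ccc(OC)c3c2OC(C)(C)C=C3)cn1` differs from compound 1 by 6-methoxypyridin-3-yl in place of 3-methoxyphenyl on a double-bonded chain carbon bound to a double-bonded chain carbon. Among the compounds with values here, no measured step between compounds is available, so in this assay the expected step is a step that the limit leaves unreadable from compound 1 to compound 4, none beyond the scatter. Compound 4 is therefore expected to give about 15000 nM in this assay, within a range of 5000 nM to 50000 nM, most probably again reported only as a limit.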

Compound 4, half-maximal inhibitory concentration: > 10000 nM
Compound 4: no number, only a limit (the forecaster's own chance of this, stated with the estimate: 80%); the middle value is on the limit's open side.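

No step from compound 1 to compound 4 can be read in this assay, since both results are only limits: the limit of > 10000 nM in this assay, at which 4 of the 4 values shown sit.

On these data alone, whether 6-methoxypyridin-3-yl in place of 3-methoxyphenyl alters activity, and how compound 1, compound 2, compound 3 and compound 4 rank, stays open.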